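The source may hold more compounds than are shown below. What is called first, only, known or untested is meant among the compounds shown, and "the series" means these compounds.

In a functional assay on cells (Homo sapiens) for inhibition, read by MTT assay, with a stated time of 72 h (on this read-out higher numbers stand for weaker inhibition and lower numbers for stronger inhibition), compound 1 `CCOC(=O)Cn1ncc2c(Nc3ccc(NC(=O)CCl)cc3)ncnc21` gives 7.27 ug/mL. Compound 2 `CCOC(=O)Cn1ncc2c(Nc3ccc(NC(C)=O)cc3)ncnc21` reaches only a limit of the assay, > 64 ug/mL, so it has no exact number. Among the measured compounds shown here, the one measured step, an at least 8.8-fold higher number from compound 1 to compound 2 (0.94 log units; beyond the scatter), replaces chloro with hydrogen within the acetyl group and shows that a small change there can move the read-out beyond the scatter. Compound 3 `CCOC(=O)Cn1ncc2c(Nc3ccc(NS(=O)(=O)c4ccc(Br)cc4)cc3)ncnc21` differs from compound 2 by (4-bromophenyl)sulfonyl in place of acetyl on a nitrogen on an aromatic ring. In words, (4-bromophenyl)sulfonyl stands in place of acetyl on a nitrogen on an aromatic ring. For the measured compounds named here, no measured step covers this exchange, so the measured step offers only a loose guide to its size. A modest move toward stronger inhibition is expected, with the estimated change being an at least 2.9-fold lower number from compound 2 to compound 3 (0.46 log units; beyond the scatter) in this assay. For compound 3, the expected value is 22 ug/mL, within an estimated range of 7 ug/mL to 64 ug/mL.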

Compound 3, half-maximal inhibitory concentration: > 64 ug/mL
Compound 3 ended at the assay's limit; the forecaster's own chance of this, stated with the estimate: 30%; middle value at least 2.9-fold (0.46 log units) from the limit.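

At this nitrogen on an aromatic ring, (4-bromophenyl)sulfonyl, a much larger group than acetyl that brings a six-membered aromatic ring, did not restore the stronger inhibition that (chloromethyl)carbonyl gives in this assay; the result is an at least 8.8-fold higher number from compound 1 to compound 3 (0.94 log units; beyond the scatter). Among the three compounds, then, two quite different replacements of (chloromethyl)carbonyl both end at the limit of the assay, so the loss seen earlier is not confined to acetyl. The step between compound 2 and compound 3 cannot be read, because both stop at the same limit: the limit of > 64 ug/mL in this assay, at which 2 of the 3 values shown sit.

Going by these compounds, it remains open how far past that limit compound 2 and compound 3 lie. On these data alone, it is also open whether another group on this nitrogen, such as bromoacetyl, a longer chloroalkanoyl chain or an acetyl carrying an amine, would give a readable number.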